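This account rests on a few compounds, and the source may have more. Where it says the series, first, only, none or still open, it means among the compounds named here.

Measured so far:
compound 1, `COC(=O)C1=C(C)NC(C)=C(C(=O)OC)C1c1csc(-c2ccc(Cl)cc2)n1`: 4430 nM
compound 2, `CCOC(=O)C1=C(C)NC(C)=C(C(=O)OCC)C1c1csc(-c2ccc(Cl)cc2)n1`: 3650 nM

Both compounds were run in an assay on isolated protein for antagonist activity at Voltage-dependent L-type calcium channel subunit alpha-1C (Cavia porcellus), with a stated time of 15 min; a lower number here means a stronger inhibitor, a higher number a weaker inhibitor. Compound 1 gives 4430 nM and compound 2 gives 3650 nM. Within the data shown here, of the two numbers the one for compound 2 is the smaller, but its gap to compound 1 lies within the scatter, so the two compounds cannot be ranked against each other. Among the measured compounds shown here, no step between measured compounds that differ in a single place is available; these two values are all the series offers.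

Compound 3, `CCOC(=O)C1=C(C)NC(C)=C(C(=O)OC)C1c1csc(-c2ccc(Cl)cc2)n1`, has not yet been run. It differs from compound 2 by hydrogen in place of methyl on a saturated chain carbon bound to an oxygen next to a carbonyl group, so one ester of compound 2 keeps its ethyl while the other carries methyl, as both esters do in compound 1. Compound 3 therefore sits between compound 1 and compound 2 in structure. Compound 1 at 4430 nM and compound 2 at 3650 nM fall within the scatter of each other. Hence the step of a 1.1-fold higher number from compound 2 to compound 3 (0.04 log units; within the scatter) is expected to stay within the scatter, with no direction that can be called. For compound 3 the estimate in this assay is 4000 nM, with a range from 2000 nM to 8000 nM.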

Compound 3, half-maximal inhibitory concentration: 22000 nM
For compound 3 the middle estimate is 5.5-fold (0.74 log units) below the measured one, outside the stated range (above it).
By their numbers in this assay, from the lowest: compounds 2 and 1 (each within the scatter of the next); then compound 3.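

In this assay this place turns out to matter, which the two matched esters alone could not show. Hydrogen in place of methyl on a saturated chain carbon bound to an oxygen next to a carbonyl group gives a 6.0-fold higher number from compound 2 to compound 3 (0.78 log units; beyond the scatter), and the reverse change, methyl in place of hydrogen at the same kind of place, gives a 5.0-fold higher number from compound 1 to compound 3 (0.70 log units; beyond the scatter). Opposite changes therefore move the number the same way, so ethyl against methyl has no single direction of its own here: the outcome depends on what the second ester carries, compound 3 with its unlike esters is the weakest of the three, and nothing available bears on the reason for this.

Going by these compounds, it remains open whether a longer chain such as a propyl ester, a branched isopropyl ester or a free carboxylic acid at this place would behave like compound 3 or return to the level of the matched esters. Also open, on these data alone, is whether the loss belongs to any pair of unlike esters or only to this pairing of methoxycarbonyl with ethoxycarbonyl.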